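Undefined ring stereocentre in the ether series

A few compounds are considered here, and "the series" means these few. Any claim that something is new, unique, unknown or untested is made for them only; others in the source may bear on it.

Compound 1 `O=C(O)CC/C=C\CO[C@H]1[C@@H](OCc2ccc(-c3ccccc3)cc2)CC[C@@H]1N1CCCCC1` gives 10 nM; 7.94 nM (2 entries) in a functional assay on blood for antagonist activity at thromboxane A2 receptor (Homo sapiens); a lower number here means tighter binding, a higher number weaker binding; the repeat entries agree with each other, (the several entries of compound 1 in this assay, 10 nM; 7.94 nM (2 entries)). Compound 2 `O=C(O)CC/C=C\CO[C@H]1[C@H](OCc2ccc(-c3ccccc3CO)cc2)CC[C@@H]1N1CCCCCC1` gives 6.31 nM in this assay. Compound 3 `CS(=O)(=O)Nc1ccccc1-c1ccc(CO[C@H]2CC[C@H](N3CCCCCC3)[C@H]2OC/C=C\CCC(=O)O)cc1` gives 6.31 nM in this assay, and compound 2 stands level with compound 3 at the digits shown, within the scatter; a further entry for compound 2 carries no single number. Compound 4 `O=C(O)CC/C=C\CO[C@H]1C(OCc2ccc(-c3ccccc3CO)cc2)CC[C@@H]1N1CCCCCC1` has not yet been measured in this assay. The change from compound 2 to compound 4 is the two compounds have the same atoms and bonds; at least one stereo element is drawn with a configuration in one of them and without one in the other: 1 of 4 stereo elements differ; a stereocentre at a saturated ring carbon is drawn R in compound 2 and without a configuration in compound 4: the two compounds have the same atoms and bonds, and one of four stereo elements differs, a stereocentre at a saturated ring carbon drawn R in compound 2 and without a configuration in compound 4. Among the compounds with values here, no measured step of this kind is available. The expectation is no change beyond the scatter, with any drift more likely towards a weaker value than a tighter one. Compound 4 is expected to give about 9 nM in this assay, within 4 nM to 25 nM, an estimated step of a 1.4-fold higher number from compound 2 to compound 4 (0.15 log units; within the scatter).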

Compound 4, dissociation constant: 3.16 nM
Compound 4: middle estimate off by 2.8-fold (0.45 log units), on the high side, outside the stated range (below it).
By their numbers in this assay, from the lowest: compounds 4, 2 and 3 (each within the scatter of the next).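

This stereocentre at a saturated ring carbon now has its first measured step in this assay, a 2.0-fold lower number from compound 2 to compound 4 (0.30 log units; within the scatter), so dropping the drawn R configuration leaves the value inside the scatter. Repeat entries of the same compound show how far values can spread in this series, which gives no ground for reading this step as a real gain: the several entries of compound 1 in this assay, 10 nM; 7.94 nM (2 entries). The step cannot be assigned to any particular configuration at this carbon, because only one member of the pair has a defined drawing: the fact that one of compounds 2 and 4 is drawn with a defined configuration and the other without, at the place where they differ

The compounds shown leave open how a compound drawn S at this carbon would read, since the R drawing is the only defined one in this pair. Also open, as far as these compounds go, is whether the same change reads alike with a carboxylic acid on the biphenyl in place of the hydroxymethyl group.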